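Benzyloxy amides against TRPM8: chloro to nitrile swap

The compounds below may be only part of what the source reports. "The series", "measured", "known", "first", "only" and "open" are said of these compounds alone.

Compound 1 `CCN(C(=O)c1ccccc1OCc1ccccc1)C1CCNCC1` and compound 2 `CN(C(=O)c1ccccc1OCc1ccccc1)[C@@H]1CCNC1` carry a secondary amine in the ring on the amide nitrogen. In an assay on HEK293 cells for inhibition of transient receptor potential cation channel subfamily M member 8 (Homo sapiens), read by FLIPR and calcium flux (on this read-out higher numbers stand for weaker inhibition and lower numbers for stronger inhibition), compound 1 returns only the limit > 5000 nM. Compound 2 likewise returns only the limit > 10000 nM. Among the compounds with values here, compound 3 `CCN(C(=O)c1ccccc1OCc1cccc(Cl)c1)C1CCCC(N)C1` is the single member with a measured number, 96.6 nM in this assay. Compound 4 `CCN(C(=O)c1ccccc1OCc1ccc(C#N)cc1)C1CCCC(N)C1` differs from compound 3 by 4-cyanophenyl in place of 3-chlorophenyl on a saturated chain carbon bound to an oxygen on an aromatic ring. Within the data shown here, with no comparable pair measured, a modest loss is expected, a 3.1-fold higher number from compound 3 to compound 4 (0.49 log units; beyond the scatter), somewhat beyond the scatter. Compound 4 is estimated at 300 nM in this assay, expected between 80 nM and 1200 nM.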

Compound 4, antagonist equilibrium constant: 4590 nM
Compound 4: middle estimate off by 15-fold (1.18 log units), on the low side; measured number above the stated range.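

In this assay, within the data shown here, the benzyl position is the first place with a readable step: 4-cyanophenyl in place of 3-chlorophenyl gives a 48-fold higher number from compound 3 to compound 4 (1.68 log units; beyond the scatter). The activity of the shared core therefore depends strongly on the group at this position, and compound 4 still gives a measured number rather than a limit. The limits recorded for the earlier compounds do not bear on this step, and nothing shown explains it. The step changes the ring substituent and its ring position together, so their contributions cannot be separated. A 3-cyanophenyl group at this place would separate them.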